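Swapping 4-methylphenyl for 3-hydroxyphenyl at an assay limit

A few compounds are considered here, and "the series" means these few. Any claim that something is new, unique, unknown or untested is made for them only; others in the source may bear on it.

Measured so far in a functional assay on HT-29 cells (Homo sapiens) for inhibition, read by MTT assay, with a stated time of 48 h; a higher number here means a weaker inhibitor, a lower number a stronger inhibitor (both values are limits, not numbers):
- compound 1 `COc1cc(-c2cc(-c3cccc([N+](=O)[O-])c3)nc(-c3ccccc3)n2)cc(OC)c1OC` gives > 25000 nM
- compound 2 `COc1cc(-c2cc(-c3ccc(C)cc3)nc(-c3ccccc3)n2)cc(OC)c1OC` gives > 25000 nM

Compound 2 stands at a limit (> 25000 nM), so it has no exact value from which to measure. Going by the values given here, compound 1 and compound 2 share the limit of > 25000 nM in this assay, at which 2 of the 2 values shown sit, as their only evidence. Compound 3 `COc1cc(-c2cc(-c3cccc(O)c3)nc(-c3ccccc3)n2)cc(OC)c1OC` carries 3-hydroxyphenyl in place of 4-methylphenyl on an aromatic carbon and keeps the rest of compound 2 unchanged. Among the compounds with values here, the one measured step that bears on this change is a step that the two limits leave unreadable from compound 1 to compound 2, so it offers no size to carry over. In this assay the expected change is a number no higher from compound 2 to compound 3 (the limit leaves the size open), an estimate with no firm direction. Compound 3 is expected at 25000 nM, with an estimated range (8000 nM to 40000 nM).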

Compound 3, half-maximal inhibitory concentration: > 25000 nM
Compound 3: only a limit was reported (the forecaster's own chance of this, stated with the estimate: 65%); the middle value lies on the limit itself.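

No step among compound 1, compound 2 and compound 3 can be read, because each is reported only as a limit: the limit of > 25000 nM in this assay, at which 3 of the 3 values shown sit.

Whether 3-nitrophenyl, 4-methylphenyl and 3-hydroxyphenyl differ in their effect in this assay stays open, as does how weak each of these compounds really is.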